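Replacing 4-chlorophenyl with 3,5-dimethoxyphenyl on the shared core

The source may report more compounds than this note shows. Statements on the series, on what has been measured and on what is new or still open speak of the compounds shown alone.

Measured compounds:
compound 1 `O=C(O)CN1C(=O)/C(=C/c2nc3ccccc3n2Cc2ccc([N+](=O)[O-])cc2)SC1=S`: 8270 nM
compound 2 `O=C(O)CN1C(=O)/C(=C/c2nc3ccccc3n2Cc2ccc(Cl)cc2)SC1=S`: 9670 nM

In a functional assay on PC-3 cells (Homo sapiens) for cytotoxicity, read by MTT assay, with a stated time of 48 h (a higher number here means a weaker inhibitor, a lower number a stronger inhibitor), compound 1 gives 8270 nM and compound 2 gives 9670 nM. Going by the values given here, compound 2 holds the highest of the two numbers, with compound 1 nearest; the one step between them, a 1.2-fold higher number from compound 1 to compound 2 (0.07 log units; within the scatter), lies within the scatter, so the two values cannot be ordered.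

Compound 3 `COc1cc(Cn2c(/C=C3\SC(=S)N(CC(=O)O)C3=O)nc3ccccc32)cc(OC)c1` differs from compound 2 by 3,5-dimethoxyphenyl in place of 4-chlorophenyl on a saturated chain carbon bound to an aromatic nitrogen. Among the compounds with values here, the only measured step, a 1.2-fold higher number from compound 1 to compound 2 (0.07 log units; within the scatter), concerns another group at another place, and it bears on this change only by showing that a swap on a peripheral ring left this assay unmoved. Within the data shown here, no step in these data reaches beyond the scatter, so no change beyond the scatter is expected here either.

Compound 3 is therefore estimated at 9000 nM, with a range from 3500 nM to 23000 nM. That estimate corresponds to an expected step of a 1.1-fold lower number from compound 2 to compound 3 (0.03 log units; within the scatter).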

Compound 3, half-maximal inhibitory concentration: 6370 nM
Beside the measured number, compound 3's estimate is 1.4-fold (0.15 log units) above it; the range from low to high includes it.
By their numbers in this assay, from the lowest: compounds 3, 1 and 2 (each within the scatter of the next).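

On the saturated chain carbon bound to an aromatic nitrogen, 3,5-dimethoxyphenyl in place of 4-chlorophenyl gives, in this assay, a 1.5-fold lower number from compound 2 to compound 3 (0.18 log units; within the scatter), and in place of 4-nitrophenyl it gives a 1.3-fold lower number from compound 1 to compound 3 (0.11 log units; within the scatter). Going by these compounds alone, the earlier pair showed only one ring substituent exchanged for another, whereas here a group of 10 heavy atoms and 2 hydrogen-bond acceptors enters for one of 7 heavy atoms and 0 acceptors, and the three compounds still cannot be told apart. No measurement is available that would link these values to any property of the groups.

Every compound shown keeps a substituted phenyl on that carbon, so it stays open whether a pyridine ring, an amine-bearing ring or a longer chain there would give a step beyond the scatter. Going by these compounds, it also stays open whether an ester or amide in place of the carboxylic acid on the shared core would shift the number in this assay.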